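This account rests on a few compounds, and the source may have more. Where it says the series, first, only, none or still open, it means among the compounds named here.

Working notes on the series.

Three analogues share one core and differ only in the group on one aromatic carbon. Compound 1 `CC1CCN(c2cc(C(F)(F)F)ccc2CNC(=O)C(C)c2ccc(NS(C)(=O)=O)c(F)c2)CC1` carries a 4-methylpiperidin-1-yl there and in an assay on CHO cells for antagonist activity at transient receptor potential cation channel subfamily V member 1 (Homo sapiens), read by FLIPR (a higher number here means a weaker inhibitor, a lower number a stronger inhibitor), compound 1 gives 0.9 nM. Compound 2 `CC(C)CCOc1cc(C(F)(F)F)ccc1CNC(=O)C(C)c1ccc(NS(C)(=O)=O)c(F)c1` carries an isopentyloxy, and in this assay compound 2 gives 0.5 nM. Compound 3 `CC(C(=O)NCc1ccc(C(F)(F)F)cc1OCc1ccc(F)cc1)c1ccc(NS(C)(=O)=O)c(F)c1` carries a (4-fluorobenzyl)oxy, and in this assay compound 3 gives 0.5 nM. Compound 3 stands level with compound 2 at the digits shown, the two together the lowest numbers of the three; the gap is a 1.8-fold lower number from compound 1 to compound 3 (0.26 log units; within the scatter), and the swap of the chain for the ring, no change at the digits printed from compound 2 to compound 3 (within the scatter), shows nothing beyond the scatter. The step of a 1.8-fold lower number from compound 1 to compound 2 (0.26 log units; within the scatter) is likewise within the scatter.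

Compound 4 `CCCCSc1cc(C(F)(F)F)ccc1CNC(=O)C(C)c1ccc(NS(C)(=O)=O)c(F)c1` is not yet measured. The change from compound 3 is butylsulfanyl in place of (4-fluorobenzyl)oxy on an aromatic carbon, placed ortho to a large group and meta to a trifluoromethyl group. The step that bears most directly is compound 2 to compound 3, where a chain and a ring on that oxygen gave the same number, and compound 1 to compound 2, where a different chain-type group also sat within the scatter. On this basis no step beyond the scatter in this assay is expected; the expected step is a 1.6-fold higher number from compound 3 to compound 4 (0.20 log units; within the scatter). Compound 4 is estimated at 0.8 nM, with a range from 0.3 nM to 2.5 nM.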

Compound 4, inhibition constant: 1.9 nM
Compound 4: the middle estimate sits 2.4-fold (0.38 log units) below what was measured; the range from low to high includes it.
By their numbers in this assay, from the lowest: compounds 2, 3 and 1 (each within the scatter of the next); then compound 4.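

At the aromatic carbon ortho to a large group and meta to a trifluoromethyl group, the three earlier groups could not be told apart in this assay, but butylsulfanyl separates from all of them beyond the scatter, though modestly (a 3.8-fold higher number from compound 3 to compound 4 (0.58 log units; beyond the scatter); a 3.8-fold higher number from compound 2 to compound 4 (0.58 log units; beyond the scatter); a 2.1-fold higher number from compound 1 to compound 4 (0.32 log units; beyond the scatter)). The position is therefore not indifferent to every replacement, and the change that matters need not involve a ring, since the step from the isopentyloxy of compound 2 has the same printed size as the step from the (4-fluorobenzyl)oxy of compound 3. Nothing shown gives a reason for these steps.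

In the change from compound 2 to compound 4, sulfur replaces oxygen on the aromatic carbon while butyl replaces isopentyl, so the two changes cannot be separated; a butoxy group or an isopentylsulfanyl group at this carbon would divide them. Also open, on these data alone, is how this position responds to a butylamino group, or to a sulfone in place of the sulfur of butylsulfanyl.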